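This account rests on a few compounds, and the source may have more. Where it says the series, first, only, none or still open, it means among the compounds named here.

Measured in a functional assay on A-431 cells (Homo sapiens) for cytotoxicity, read by MTT assay, with a stated time of 72 h; on this read-out lower numbers stand for stronger inhibition and higher numbers for weaker inhibition:
- compound 2 `Cc1cccc(/C(N)=N/NC(=S)N2CCSCC2)n1`: 2600 nM
- compound 1 `N/C(=N\NC(=S)N1CCN(c2ccccn2)CC1)c1ccc(F)cn1`: 13400 nM
- compound 3 `Cc1ccnc(/C(N)=N/NC(=S)N2CCN(c3ccccn3)CC2)c1`: 15500 nM

Compound 2 gives the lowest number of the three, separated from compound 1 and compound 3 by gaps that are beyond the scatter. Compound 4 `N/C(=N\NC(=S)N1CCSCC1)c1ccccn1` differs from it by hydrogen in place of methyl on an aromatic carbon; the place is an aromatic carbon of a six-membered aromatic ring with 1 nitrogen, next to the ring nitrogen, meta to a large group. For the measured compounds named here, the only measured step touching that ring is a 1.2-fold higher number from compound 1 to compound 3 (0.06 log units; within the scatter), where a different ring substituent left the number essentially unchanged. Removing the methyl is a smaller change again, so no step beyond the scatter is expected in this assay. Compound 4 is therefore estimated at 3500 nM (range 1200 nM to 10000 nM), a step of a 1.3-fold higher number from compound 2 to compound 4 (0.13 log units; within the scatter).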

Compound 4, half-maximal inhibitory concentration: 6700 nM
Beside the measured number, compound 4's estimate is 1.9-fold (0.28 log units) below it; the range from low to high includes it.
By their numbers in this assay, from the lowest: compound 2; then compounds 4, 1 and 3 (each within the scatter of the next, the first and the last beyond it).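

Replacing the methyl with hydrogen in this assay gives a 2.6-fold higher number from compound 2 to compound 4 (0.41 log units; beyond the scatter) and so costs some inhibition. For the compounds shown here, the only earlier step on this ring, a 1.2-fold higher number from compound 1 to compound 3 (0.06 log units; within the scatter), showed no clear change, whereas this one shows that a single carbon on the aromatic carbon next to the ring nitrogen can matter, though modestly. No measurement here accounts for this step. On these data alone, whether an ethyl group or an amine at this carbon would lower the number further remains open, as does whether removing the methyl matters equally in the larger compounds, compound 1 and compound 3.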